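This account rests on a few compounds, and the source may have more. Where it says the series, first, only, none or still open, it means among the compounds named here.

Compound 2 `O=C(Nc1ccc(S(=O)(=O)N2CCC(Cl)CC2)cc1)c1ccc([N+](=O)[O-])o1` gives 800 nM in an assay on CHO-K1 cells for activation of DNA damage-inducible transcript 3 protein (Homo sapiens), read by a luciferase reporter (on this read-out lower numbers stand for an effect already at smaller amounts and higher numbers for an effect only at larger amounts of compound), the lower of the two numbers recorded so far, with compound 1 `CC1CN(S(=O)(=O)c2ccc(NC(=O)c3ccc([N+](=O)[O-])o3)cc2)CC(C)O1` nearest at 1400 nM. For the measured compounds named here, the one measured step, a 1.8-fold lower number from compound 1 to compound 2 (0.24 log units; within the scatter), exchanged the ring on the sulfonyl sulfur and stayed within the scatter. Compound 3 `CC(C)(C)C1CCN(S(=O)(=O)c2ccc(NC(=O)c3ccc([N+](=O)[O-])o3)cc2)CC1` differs from compound 2 by tert-butyl in place of chloro on a saturated ring carbon, again a change on that same ring. Going by the values given here, since the only comparable step was within the scatter, the expected step is no change at the digits printed from compound 2 to compound 3 (within the scatter), none beyond the scatter. Compound 3 is therefore estimated at 800 nM, within a range of 250 nM to 2600 nM.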

Compound 3, concentration for half-maximal activity: 700 nM
Estimate against measurement, compound 3: 1.1-fold (0.06 log units) above; the range from low to high includes it.
By their numbers in this assay, from the lowest: compounds 3, 2 and 1 (each within the scatter of the next).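

In this assay the exchange of chloro for tert-butyl gives a 1.1-fold lower number from compound 2 to compound 3 (0.06 log units; within the scatter) at this saturated ring carbon, three ring bonds from the ring nitrogen, so 4 carbon atoms here read the same as 1 chlorine atom. The whole exchange on the sulfonyl sulfur, 4-(tert-butyl)piperidin-1-yl in place of 2,6-dimethylmorpholin-4-yl, gives a 2.0-fold lower number from compound 1 to compound 3 (0.30 log units; within the scatter) and likewise does not separate the two compounds. Nothing available accounts for this sameness. From the compounds shown here alone, whether an amine or a carboxylic acid on this ring carbon would give a number in the same range stays open.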